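Replacing hydroxy with chloro in compound 3

This account rests on a few compounds, and the source may have more. Where it says the series, first, only, none or still open, it means among the compounds named here.

In a functional assay on microsomes for inhibition, with a stated time of 1 h (a lower number here means a stronger inhibitor, a higher number a weaker inhibitor), compound 1 (`COc1ccc(-c2nc(NN)n(C)c(=O)c2C#N)cc1`) stands at 39 ug/mL and compound 2 (`CSc1nc(-c2ccco2)c(C#N)c(=O)n1C`) stands at 90 ug/mL on the same scale. Compound 3 (`CCOC(=O)c1cnn(-c2nc(-c3ccccc3O)c(C#N)c(=O)n2C)c1N`) reads 57 ug/mL and lies within the usual scatter of both compound 1 and compound 2.

Compound 4 (`CCOC(=O)c1cnn(-c2nc(-c3ccccc3Cl)c(C#N)c(=O)n2C)c1N`) has not yet been measured. It carries chloro in place of hydroxy on an aromatic carbon, ortho to a large group, so that the 2-hydroxyphenyl of compound 3 becomes 2-chlorophenyl (chloro in place of hydroxy on an aromatic carbon).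

Within the data shown here, no two measured compounds differ in one place only, so the data give no direct reading of this exchange. Among the measured compounds shown here, they show only that three compounds with quite different groups on the shared core give similar numbers, with compound 3 at 57 ug/mL within the scatter of the other two. On that basis, no change beyond the scatter is expected in either direction. The estimated step of a 1.1-fold lower number from compound 3 to compound 4 (0.06 log units; within the scatter) stays within the scatter. Compound 4 is estimated at 50 ug/mL with an expected range from 22 ug/mL to 115 ug/mL ahead of its measurement.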

Compound 4, half-maximal inhibitory concentration: 102 ug/mL
Compound 4: the middle estimate sits 2.0-fold (0.31 log units) below what was measured; low and high end bracket the measured number.
By their numbers in this assay, from the lowest: compounds 1, 3, 2 and 4 (each within the scatter of the next, the first and the last beyond it).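

In this assay, the exchange of hydroxy for chloro on an aromatic carbon, ortho to a large group, now has a direct reading, the first from a pair differing in one place: a 1.8-fold higher number from compound 3 to compound 4 (0.25 log units; within the scatter). For this one pair, then, 2-hydroxyphenyl and 2-chlorophenyl on the shared core cannot be told apart in this assay, even though hydroxy counts as a hydrogen-bond donor and acceptor and chloro as neither. Nothing shown bears on why the two groups read alike here.

The compounds shown leave open how an amine, a carboxylic acid or a fluoro group would read at this place on the ring, and whether any group there can give a step beyond the scatter. They also leave open whether chloro in place of hydroxy would read the same way with other groups on the shared core, since this exchange is seen in a single pair.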